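From Methyl to Acetyl on a Ring Amine Nitrogen

The compounds below may be only part of what the source reports. "The series", "measured", "known", "first", "only" and "open" are said of these compounds alone.

For the measured compounds named here, compound 1 `N#CCN(Cc1ccc(Cl)cc1)Cc1ccc([N+](=O)[O-])s1` is the only member of this small set with a number: in a functional assay on HEK293 cells for agonist activity at nuclear receptor subfamily 1 group D member 1 (Homo sapiens), read by a luciferase reporter, with a stated time of 24 h (on this read-out lower numbers stand for an effect already at smaller amounts and higher numbers for an effect only at larger amounts of compound), compound 1 gives 2500 nM. For compound 2 `CN1CCC(CN(Cc2ccc(Cl)cc2)Cc2ccc([N+](=O)[O-])s2)C1` the result in this assay is given as "not determined" (no result reported), so compound 2 stands without a number of its own. Compound 3 `CC(=O)N1CCC(CN(Cc2ccc(Cl)cc2)Cc2ccc([N+](=O)[O-])s2)C1` differs from compound 2 by acetyl in place of methyl on an amine nitrogen in a ring. Going by the values given here, with no measured step of this kind to lean on, no shift beyond the usual scatter is expected in either direction for this assay. Compound 3 is therefore estimated at 2500 nM, with a likely range from 600 nM to 10000 nM.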

Compound 3, half-maximal effective concentration: 1600 nM
Estimate against measurement, compound 3: 1.6-fold (0.19 log units) above, within the range that was stated.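

In this assay, 1-acetylpyrrolidin-3-yl in place of cyano on a saturated chain carbon bound to an amine nitrogen gives a 1.6-fold lower number from compound 1 to compound 3 (0.19 log units; within the scatter), so this position accepts the acetylated ring with no shift beyond the usual scatter. The change from methyl to acetyl itself cannot be read, since compound 2 has no number. Nothing available explains the result. Still open, going by these compounds, is how a longer acyl chain, a sulfonyl group or a bare hydrogen on the amine nitrogen in the ring would read out.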